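The compounds below may be only part of what the source reports. "The series", "measured", "known", "first", "only" and "open" are said of these compounds alone.

Measured in an ADME assay on HepG2 2.2.15 cells (Homo sapiens) for cytotoxicity, read by MTT assay; on this read-out higher numbers stand for lower toxicity in this test and lower numbers for higher toxicity in this test:
- compound 1 `C=C1CC[C@@H]2[C@](C)(COC(=O)/C=C/c3ccccc3)[C@H](O)CC[C@@]2(C)[C@@H]1/C=C/C1=CCOC1=O`: 183000 nM
- compound 2 `C=C1CC[C@@H]2[C@](C)(COC(=O)/C=C/c3cccc(OC)c3)[C@H](O)CC[C@@]2(C)[C@@H]1/C=C/C1=CCOC1=O`: > 1970000 nM

As far as these compounds go, compound 2 gives only a limit, > 1970000 nM, so its true position is unknown. Compound 3 `C=C1CC[C@@H]2[C@](C)(COC(=O)/C=C/c3cc(OC)c(OC)c(OC)c3)[C@H](O)CC[C@@]2(C)[C@@H]1/C=C/C1=CCOC1=O` differs from it in one place: 3,4,5-trimethoxyphenyl in place of 3-methoxyphenyl on a double-bonded chain carbon bound to a double-bonded chain carbon. Among the compounds with values here, the one measured step that bears on this is an at least 10-fold higher number from compound 1 to compound 2 (1.03 log units; beyond the scatter), which is large and beyond the scatter. It also added a methoxy group, so compound 3 is expected to stay in the same high region of this assay, with no large step in either direction. The expected change is an at least 1.6-fold lower number from compound 2 to compound 3 (0.21 log units; that floor lies within the scatter). For compound 3 the estimate is 1200000 nM, with a range of 300000 nM to 2000000 nM.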

Compound 3, half-maximal cytotoxic concentration: > 1700000 nM
Compound 3: a limit, no number; the forecaster's own chance of this, stated with the estimate: 50%; at least 1.4-fold (0.15 log units) between middle value and limit.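

In this assay compound 3 gives only a limit, > 1700000 nM. The 3,4,5-trimethoxyphenyl group in place of phenyl gives an at least 9.2-fold higher number from compound 1 to compound 3 (0.96 log units; beyond the scatter), so at this place a ring with three methoxy groups, like 3-methoxyphenyl, lies clear of compound 1 on the side of lower toxicity in this test. The step between compound 2 and compound 3 cannot be read, since both values are limits.

As far as these compounds go, the true values of these two compounds remain open. So does whether a ring bearing a hydroxyl group or an amine would behave the same way at this place.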